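A few compounds are considered here, and "the series" means these few. Any claim that something is new, unique, unknown or untested is made for them only; others in the source may bear on it.

Working notes on the series. The shared core is that of compound 1 `Cn1c(/C=C2\SC(=O)N(CC(=O)Nc3cc(C(C)(C)C)on3)C2=O)nc2ccccc21`. Among the compounds with values here, in a functional assay on MDA-MB-231 cells (Homo sapiens) for inhibition, read by MTT assay, with a stated time of 48 h (a lower number here means a stronger inhibitor, a higher number a weaker inhibitor), compound 1 gives 33800 nM, the only number in the set. Compound 2 `CC(C)n1c(/C=C2\SC(=O)N(CC(=O)N3CCCCC3)C2=O)nc2ccccc21` belongs to the same set. In this assay compound 2 returns only > 50000 nM, a limit of the assay and not a number. One of the two values therefore sits at the limit of > 50000 nM in this assay, at which 1 of the 2 values shown sits. Compound 1 thus stands as the single measured point, with the other entry a limit.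

Compound 3 `Cn1c(/C=C2\SC(=O)N(CC(=O)N3CCOCC3)C2=O)nc2ccccc21` differs from compound 1 by morpholin-4-yl in place of (5-(tert-butyl)-1,2-oxazol-3-yl)amino on a carbonyl carbon. Within the data shown here, no measured step for such a change exists in the set, so the size of the step must be estimated. The expectation for this assay is a move from compound 1 toward weaker inhibition, beyond the scatter, of about a 1.6-fold higher number from compound 1 to compound 3 (0.21 log units; within the scatter). Compound 3 is estimated at 55000 nM, with a range of 20000 nM to 150000 nM, and a fair chance that only a limit is returned.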

Compound 3, half-maximal inhibitory concentration: > 50000 nM
Compound 3: a limit, no number; the forecaster's own chance of this, stated with the estimate: 55%; the middle value is on the limit's open side.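

For compound 3 the result in this assay is > 50000 nM, which is a limit of the assay and not a number. Morpholin-4-yl in place of (5-(tert-butyl)-1,2-oxazol-3-yl)amino on a carbonyl carbon gives an at least 1.4-fold higher number from compound 1 to compound 3 (0.17 log units; that floor lies within the scatter), so this change has a floor inside the scatter and no upper bound, and neither its true size nor a real loss can be read from it. At this position the read-out can now be seen to reach the assay's limit with the core of compound 1 otherwise unchanged, and limits now make up most of the set: the limit of > 50000 nM in this assay, at which 2 of the 3 values shown sit.

On these data alone, it remains open how a phenylamino group or a (5-methyl-1,2-oxazol-3-yl)amino group would read on this carbonyl carbon. The compounds shown therefore do not separate the contribution of the tert-butyl group from that of the amide hydrogen or the aromatic ring.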